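Swapping the Pyrimidine Ring for a Fluorophenyl Group

The compounds below may be only part of what the source reports. "The series", "measured", "known", "first", "only" and "open" are said of these compounds alone.

Compound 3 `CC(C)n1ncc2c(C(=O)Nc3cncnc3)cc(-c3cccs3)nc21` is one of three close relatives built on a shared core. In an ADME assay on LLC-MK2 cells (Macaca mulatta) for cytotoxicity, read by spectrophotometry and crystal violet staining, with a stated time of 4 days (on this read-out higher numbers stand for lower toxicity in this test and lower numbers for higher toxicity in this test), compound 3 gives 20000 nM, the lowest of the two numbers reported; compound 1 `CC(C)n1ncc2c(C(=O)Nc3cc(S(N)(=O)=O)ccc3F)cc(-c3cccs3)nc21` sits nearby with 25000 nM, a gap within the scatter. Compound 2 `CC(C)n1ncc2c(C(=O)Nc3cccnc3)cc(-c3cccs3)nc21` reports only a limit, > 200000 nM. Going by the values given here, the single measured step, an at least 10-fold lower number from compound 2 to compound 3 (1.00 log units; beyond the scatter), shows that exchanging the ring on the amide-type nitrogen can shift this read-out strongly. Compound 4 `CC(C)n1ncc2c(C(=O)Nc3ccccc3F)cc(-c3cccs3)nc21` differs from compound 3 by 2-fluorophenyl in place of pyrimidin-5-yl on an amide-type nitrogen. Among the compounds with values here, no measured step covers this exact exchange, so its direction stays open. Compound 4 is therefore expected near 30000 nM, between 8000 nM and 150000 nM, an estimated step of a 1.5-fold higher number from compound 3 to compound 4 (0.18 log units; within the scatter).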

Compound 4, half-maximal cytotoxic concentration: 50000 nM
Estimate against measurement, compound 4: 1.7-fold (0.22 log units) below, and the stated range covers the measured number.
By their numbers in this assay, from the lowest: compounds 3, 1 and 4 (each within the scatter of the next, the first and the last beyond it). At a limit, above all of these: compound 2.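

In this assay, the carbon-only 2-fluorophenyl ring on the amide-type nitrogen gives a 2.5-fold higher number from compound 3 to compound 4 (0.40 log units; beyond the scatter), so the number at this position does not depend only on rings that contain nitrogen. Replacing sulfamoyl with hydrogen on the aromatic carbon stays within the scatter: a 2.0-fold higher number from compound 1 to compound 4 (0.30 log units; within the scatter). The step of an at least 4.0-fold lower number from compound 2 to compound 4 (0.60 log units; beyond the scatter) rests on a limit of the assay and not on a number: the limit of > 200000 nM in this assay, at which 1 of the 4 values shown sits.

On these data alone, what a plain phenyl ring would give on this nitrogen stays open, so the part played by the fluorine cannot be separated from that of the ring. As far as these compounds go, a carboxylic acid in place of the sulfamoyl group also stays open.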